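From compound 3 to compound 4: a 2-hydroxypropyl chain

The source may report more compounds than this note shows. Statements on the series, on what has been measured and on what is new or still open speak of the compounds shown alone.

Measured in a functional assay on cells (Neutrophil, Homo sapiens) for inhibition, with a stated time of 10 min; a higher number here means a weaker inhibitor, a lower number a stronger inhibitor:
compound 1 `CCOC(=O)c1cnn(CC(C)O)c1NC(=O)Nc1ccc(F)cc1`: 0.2 nM
compound 2 `CCOC(=O)c1cnn(CC(C)O)c1NC(=O)Nc1ccccc1F`: 0.00055 nM
compound 3 `CCOC(=O)c1cnn(C)c1NC(=O)NC(C)C`: 0.0018 nM

Compound 3, at 0.0018 nM, holds the second highest of the three numbers. Compound 1 at 0.2 nM gives a higher number, and compound 2 at 0.00055 nM gives a lower one. Compound 4 `CCOC(=O)c1cnn(CC(C)O)c1NC(=O)NC(C)C` differs from compound 3 by 1-hydroxyethyl in place of hydrogen on a saturated chain carbon bound to an aromatic nitrogen. This is 1-hydroxyethyl in place of hydrogen on a saturated chain carbon bound to an aromatic nitrogen, which read one bond further out is methyl to 2-hydroxypropyl.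

Within the data shown here, no measured step makes this exchange. Among the measured compounds shown here, the only step available is a 360-fold lower number from compound 1 to compound 2 (2.56 log units; beyond the scatter), a large one, beyond the scatter, and the 2-hydroxypropyl chain stays the same across it. It shows that, with this chain in place, the number can move strongly when another part of the molecule changes. Compound 1 and compound 2 both carry the chain, yet their values lie on either side of the value of compound 3, so they fix no direction. A modest move to a higher number is expected in this assay, though with little certainty. The expected size is a 2.2-fold higher number from compound 3 to compound 4 (0.35 log units; beyond the scatter). For compound 4 the estimate is 0.004 nM, with an expected range from 0.0005 nM to 0.05 nM.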

Compound 4, half-maximal inhibitory concentration: 0.00082 nM
For compound 4 the middle estimate is 4.9-fold (0.69 log units) above the measured one; the range from low to high includes it.
By their numbers in this assay, from the lowest: compounds 2 and 4 (each within the scatter of the next); then compound 3; then compound 1.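

In this assay, the exchange of methyl for 2-hydroxypropyl can now be read directly, with isopropyl held on the amide-type nitrogen: the step is a 2.2-fold lower number from compound 3 to compound 4 (0.34 log units; beyond the scatter) and shows that, in this pair, the added chain does not raise the number. With the 2-hydroxypropyl chain held constant, the group on the amide-type nitrogen can also be compared in a third form: isopropyl in place of 2-fluorophenyl gives a 1.5-fold higher number from compound 2 to compound 4 (0.17 log units; within the scatter) while isopropyl in place of 4-fluorophenyl gives a 240-fold lower number from compound 1 to compound 4 (2.39 log units; beyond the scatter) as its step. Among the three compounds carrying this chain, isopropyl and 2-fluorophenyl therefore cannot be told apart, and only the 4-fluorophenyl compound stands clearly apart, with the higher number.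

Going by these compounds, whether the chain gives a similar step when a fluorophenyl group sits on the amide-type nitrogen remains open, as does what a 3-hydroxypropyl chain or a carboxylic acid at the end of the chain would do at this place. Nothing in the available data explains any of these shifts.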